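The source may report more compounds than this note shows. Statements on the series, on what has been measured and on what is new or still open speak of the compounds shown alone.

Measured in a functional assay on HeLa cells (Homo sapiens) for antiproliferative activity, read by MTT assay, with a stated time of 48 h; a higher number here means a weaker inhibitor, a lower number a stronger inhibitor:

- compound 1 `Cc1ccc2[nH]c(-c3cn(-c4ccccc4)nc3-c3ccccc3)nc2c1` gives 6560 nM
- compound 2 `COc1ccc2[nH]c(-c3cn(-c4ccccc4)nc3-c3ccccc3)nc2c1` gives 2870 nM
- compound 3 `O=C(OCc1ccccc1)c1ccc2[nH]c(-c3cn(-c4ccccc4)nc3-c3ccccc3)nc2c1` gives 21300 nM

Compound 3 carries the highest number of the three in this assay and is thus the weakest of this small set, with both of its gaps beyond the scatter. The step now in question leads to compound 4 `O=C(OCc1ccccc1)c1ccc2[nH]c(-c3cn(-c4ccccc4)nc3-c3ccc(F)cc3)nc2c1`, which keeps the benzyloxycarbonyl group of compound 3 and changes a phenyl to a 4-fluorophenyl. The difference is fluoro in place of hydrogen on an aromatic carbon.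

Three measured steps are available: a 2.3-fold lower number from compound 1 to compound 2 (0.36 log units; beyond the scatter), a 3.2-fold higher number from compound 1 to compound 3 (0.51 log units; beyond the scatter) and a 7.4-fold higher number from compound 2 to compound 3 (0.87 log units; beyond the scatter). All three are modest, but each exchanges the methyl, methoxy or benzyloxycarbonyl group, and none touches the ring that gains the fluoro. Among the measured compounds shown here, the data therefore hold no direct precedent for this change, and they give no firm direction for it. With so small an exchange, no step beyond the scatter is expected, and the estimate leans only slightly downward, as a 1.3-fold lower number from compound 3 to compound 4 (0.12 log units; within the scatter). For compound 4 the expected value is 16000 nM, and the estimated range runs from 6500 nM to 35000 nM.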

Compound 4, half-maximal inhibitory concentration: 23600 nM
For compound 4 the middle estimate is 1.5-fold (0.17 log units) below the measured one, and the stated range covers the measured number.
By their numbers in this assay, from the lowest: compound 2; then compound 1; then compounds 3 and 4 (each within the scatter of the next).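

In this assay, among the compounds shown here, this is the first step in the set to touch the phenyl ring that gains the fluoro, and it reads as a 1.1-fold higher number from compound 3 to compound 4 (0.04 log units; within the scatter). With the benzyloxycarbonyl group held constant, fluoro in place of hydrogen on this aromatic carbon, para to a large group, therefore gives two compounds that cannot be told apart, whereas the three earlier exchanges of the methyl, methoxy and benzyloxycarbonyl groups all gave steps beyond the scatter. No measurement of any property of these compounds bears on this result, so the data offer no account of it.

Going by these compounds, since this is a single pair, it remains open whether the same fluoro exchange would also stay within the scatter alongside the methyl of compound 1 or the methoxy of compound 2, the two lower numbers in the set. On these data alone, it is equally open whether a chloro, an amine or a carboxylic acid on the same carbon would shift the number, or whether fluoro would behave the same way on the other phenyl ring of the core.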